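Ethoxycarbonyl Added on the Nitrogen Chain: An Expectation

The source may report more compounds than this note shows. Statements on the series, on what has been measured and on what is new or still open speak of the compounds shown alone.

Measured so far:
compound 1, `COc1ccc2cc(-c3ccccc3)c(O)nc2c1`: 10000 nM
compound 2, `COc1ccc(-c2cc3cccc(OC)c3nc2O)cc1`: 10000 nM
compound 3, `COc1ccc(-c2cc3c(OC)cc(OC)cc3n(C)c2=O)cc1`: 10000 nM

In a functional assay on T47D cells (Homo sapiens) for cytotoxicity, read by colorimetric assay and MTT assay (on this read-out lower numbers stand for stronger inhibition and higher numbers for weaker inhibition), compound 1 gives 10000 nM. Compound 2 gives 10000 nM, and compound 3 gives 10000 nM. At the digits shown, compound 3 stands level with compound 1 and compound 2; the three values lie within the usual scatter of each other, so none of them can be called stronger or weaker.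

Compound 4, `CCOC(=O)Cn1c(=O)c(-c2ccc(OC)cc2)cc2c(OC)cc(OC)cc21`, has not been measured. Its change from compound 3 is ethoxycarbonyl in place of hydrogen on a saturated chain carbon bound to an aromatic nitrogen; cut one bond further out, it reads methyl to (ethoxycarbonyl)methyl. Among the compounds with values here, no measured pair shows a comparable step, so nothing here points to a direction. The step of no change at the digits printed from compound 3 to compound 4 (within the scatter) is expected to stay within the scatter. For compound 4 the expected value is 10000 nM, ranging from 3000 nM to 30000 nM.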

Compound 4, half-maximal inhibitory concentration: 10000 nM
Compound 4: the middle estimate sits on the measured number at the digits printed, within the range that was stated.
By their numbers in this assay, from the lowest: compounds 1, 2, 3 and 4 (each within the scatter of the next).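

In this assay, within the data shown here, putting ethoxycarbonyl in place of hydrogen on a saturated chain carbon bound to an aromatic nitrogen gives no change at the digits printed from compound 3 to compound 4 (within the scatter) and this is the first single change that can be read. The earlier compounds shown here offered no pair differing in one place, so this position had no reading until now. Nothing at hand speaks to why the number holds. On these data alone, whether a carboxylic acid or an amine on this chain, or a longer chain, would shift the value stays open.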